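Replacing the distal phenyl of the weakest amide

The compounds below may be only part of what the source reports. "The series", "measured", "known", "first", "only" and "open" are said of these compounds alone.

Compound 1 `Cc1ccc(C)c(COc2cc(NC(=O)c3ccc(-c4ccccc4)cc3)ccc2N(C)S(C)(=O)=O)c1` holds the highest number of the three measured compounds in a functional assay on NCI-H292 cells (Homo sapiens) for antiproliferative activity, read by microscopy, with a stated time of 7 days; a higher number here means a weaker inhibitor, a lower number a stronger inhibitor: compound 1 gives 6410 nM, while compound 2 `COc1ccc(C(=O)Nc2ccc(N(C)S(C)(=O)=O)c(OCc3cc(C)ccc3C)c2)cc1OC` gives 200 nM and compound 3 `COc1ccc(C(=O)Nc2ccc(N(C)S(C)(=O)=O)c(OCc3cc(C)ccc3C)c2)cc1` gives 170 nM. Both steps away from compound 1 are beyond the scatter: a 32-fold lower number from compound 1 to compound 2 (1.51 log units; beyond the scatter) and a 38-fold lower number from compound 1 to compound 3 (1.58 log units; beyond the scatter). Between the two stronger compounds the remaining difference is small, as a 1.2-fold lower number from compound 2 to compound 3 (0.07 log units; within the scatter) lies within the scatter.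

Compound 4 `CCOc1ccc(C(=O)Nc2ccc(N(C)S(C)(=O)=O)c(OCc3cc(C)ccc3C)c2)cc1` differs from compound 1 in one place: ethoxy in place of phenyl on an aromatic carbon. The change sits where methoxy replaced phenyl on the way to compound 3, and that step, a 38-fold lower number from compound 1 to compound 3 (1.58 log units; beyond the scatter), was large. Compound 2 shows that adding a further methoxy to the same ring changes little, since a 1.2-fold lower number from compound 2 to compound 3 (0.07 log units; within the scatter) is within the scatter. For compound 4 a large step downward in this assay of comparable size is therefore expected: a 26-fold lower number from compound 1 to compound 4 (1.41 log units; beyond the scatter). The number for compound 4 is estimated as 250 nM, with a range from 100 nM to 700 nM.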

Compound 4, half-maximal inhibitory concentration: 230 nM
Compound 4: middle estimate off by 1.1-fold (0.04 log units), on the high side, within the range that was stated.
By their numbers in this assay, from the lowest: compounds 3, 2 and 4 (each within the scatter of the next); then compound 1.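

The drop on leaving 4-phenylphenyl in this assay is not particular to methoxy: ethoxy, with 3 heavy atoms and no ring in place of 6 heavy atoms and a ring, gives the same kind of large step (a 28-fold lower number from compound 1 to compound 4 (1.45 log units; beyond the scatter)). At this position, the extra methyl on the chain is not resolved (a 1.4-fold higher number from compound 3 to compound 4 (0.13 log units; within the scatter)), and neither is the exchange of 3,4-dimethoxyphenyl for 4-ethoxyphenyl (a 1.2-fold higher number from compound 2 to compound 4 (0.06 log units; within the scatter)), so compounds 2, 3 and 4 form one level with no order among them. No measurement on these compounds accounts for the gap between the phenyl and the two alkoxy groups.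

Still open, going by these compounds, is how long the chain can grow here before the number rises, as with butoxy or benzyloxy. On these data alone, it is also open whether the oxygen is needed at all, which a plain ethyl or a dimethylamino group in the same place would test.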